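Cytotoxicity notes: dichlorobenzyl in place of dimethylbenzyl

The source may report more compounds than this note shows. Statements on the series, on what has been measured and on what is new or still open speak of the compounds shown alone.

The series shares one core, carried in compound 1 `Cc1cc(C)cc(Cn2cc(Nc3ccccc3)c(=O)[nH]c2=O)c1`, compound 2 `Cc1ccc(Nc2cn(Cc3ccc(Cl)cc3Cl)c(=O)[nH]c2=O)cc1`, compound 3 `Cc1cc(C)cc(Cn2cc(NCc3ccccc3)c(=O)[nH]c2=O)c1` and the unmeasured compound 4 `O=c1[nH]c(=O)n(Cc2ccc(Cl)cc2Cl)cc1NCc1ccccc1`. In an ADME assay on CEM-SS cells (Homo sapiens) for cytotoxicity, read by XTT assay (a higher number here means that more compound is tolerated, a lower number that less compound is tolerated), compound 1 gives only a limit, > 200000 nM, which is the assay limit noted as the limit of > 200000 nM in this assay, at which 1 of the 3 values shown sits. In this assay, within the data shown here, compound 3 gives 168000 nM, the only actual number in the set. For compound 2 this assay has "not determined" (no result reported). Compound 3 therefore stands as the sole numeric point; one further value is a limit and one entry has no number.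

Among the measured compounds shown here, the single measured step, an at least 1.1-fold lower number from compound 1 to compound 3 (0.07 log units; that floor lies within the scatter), concerns the substituent on the amine nitrogen and does not touch the benzyl aryl ring. The change to compound 4 is 2,4-dichlorophenyl in place of 3,5-dimethylphenyl on a saturated chain carbon bound to an aromatic nitrogen. Compound 2 carries the same 2,4-dichlorophenyl group, but without a result it gives no guidance. For the measured compounds named here, no measured step therefore bears on this change, and the step of a 1.1-fold lower number from compound 3 to compound 4 (0.05 log units; within the scatter) is expected to be none beyond the scatter.

Compound 4 is estimated in this assay at 150000 nM, within 60000 nM to 400000 nM, with a fair chance that only a limit is reported.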

Compound 4, half-maximal cytotoxic concentration: > 100000 nM
Compound 4: only a limit was reported; the forecaster's own chance of this, stated with the estimate: 40%; the middle value does not contradict the limit.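

In this assay compound 4 gives > 100000 nM as a limit, not a number. The step from compound 3 to compound 4 therefore cannot be read. The compounds shown leave open whether 2,4-dichlorophenyl in place of 3,5-dimethylphenyl changes the tolerated concentration at all, and compound 2 offers no result to settle it.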